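A sulfur link in place of the benzylamine

This account rests on a few compounds, and the source may have more. Where it says the series, first, only, none or still open, it means among the compounds named here.

Measured in a functional assay on TK-10 cells (Homo sapiens) for inhibition, read by sulforhodamine B assay, with a stated time of 48 h; a higher number here means a weaker inhibitor of growth, a lower number a stronger inhibitor of growth:
Compound 1 `Nc1cc(N)c2nc(-c3ccccc3)c(NCc3ccc(Cl)c(Cl)c3)nc2c1` gives 30200 nM.
Compound 2 `Nc1cc(N)c2nc(-c3ccccc3)c(NCc3ccc(F)cc3)nc2c1` gives 20000 nM.
Compound 3 `COc1ccc(CNc2nc3cc(N)cc(N)c3nc2-c2ccccc2)cc1` gives 57500 nM.

Compound 2 has the lowest number of the three. Its nearest neighbour is compound 1: a 1.5-fold lower number from compound 1 to compound 2 (0.18 log units; within the scatter), which keeps the two within the scatter of each other. The furthest is compound 3: a 2.9-fold higher number from compound 2 to compound 3 (0.46 log units; beyond the scatter), a modest step that does clear the scatter. Compound 1 and compound 3 sit within the scatter of each other: a 1.9-fold higher number from compound 1 to compound 3 (0.28 log units; within the scatter).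

Compound 4 `Nc1cc(N)c2nc(-c3ccccc3)c(Sc3ccc(Cl)c(Cl)c3)nc2c1` is the next compound. Going from compound 2, the change is (3,4-dichlorophenyl)sulfanyl in place of (4-fluorobenzyl)amino on an aromatic carbon. Within the data shown here, of the measured steps, only the one from compound 1 to compound 2 touches the 3,4-dichlorophenyl group, and it was small: a 1.5-fold lower number from compound 1 to compound 2 (0.18 log units; within the scatter). Among the measured compounds shown here, no measured step changes the link between the shared core and the aryl group, so that part of the change is unexplored here.

On this basis compound 4 is expected to land close to compound 1, with an estimated step of a 1.5-fold higher number from compound 2 to compound 4 (0.18 log units; within the scatter) in this assay. The estimate for compound 4 is 30000 nM, with a range from 10000 nM to 90000 nM.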

Compound 4, concentration for total growth inhibition: 20000 nM
Compound 4: middle estimate off by 1.5-fold (0.18 log units), on the high side; the range from low to high includes it.
By their numbers in this assay, from the lowest: compounds 2, 4, 1 and 3 (each within the scatter of the next, the first and the last beyond it).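

Among these compounds, replacing the whole (4-fluorobenzyl)amino group with (3,4-dichlorophenyl)sulfanyl on this aromatic carbon of the shared core gives no change at the digits printed from compound 2 to compound 4 (within the scatter) in this assay, so at this position a group with 0 hydrogen-bond donors reads the same as one with 1 hydrogen-bond donor, something the earlier compounds, which all kept the benzylamine link, could not show. Compound 1, which carries the same 3,4-dichlorophenyl group on the benzylamine link, gives 30200 nM, and compound 4, with that group on sulfur, gives 20000 nM, so the printed values of this pair are the only view of the link with the aryl group held constant. Nothing available explains why the numbers of compound 2 and compound 4 coincide, and no measurement bears on it.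

The step from compound 2 changes the link and the aryl group together, so the share of each cannot be told apart, and a (4-fluorophenyl)sulfanyl group would be the direct partner for separating them. Also open, going by these compounds, is how an oxygen link, a sulfonyl link or a longer chain between the core and the aryl ring would read at this carbon.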